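Working notes: 1-benzofuran-2-yl in place of thiophen-2-yl

This account rests on a few compounds, and the source may have more. Where it says the series, first, only, none or still open, it means among the compounds named here.

Measured so far in an ADME assay on BJ cells (Homo sapiens), read by MTT assay, with a stated time of 72 h (on this read-out higher numbers stand for weaker inhibition and lower numbers for stronger inhibition), as follows:
- compound 1 `COc1ncnc2c1c(-c1cc3ccccc3o1)cn2[C@@H]1O[C@H](CO)[C@@H](O)[C@H]1O` gives 22400 nM as a number
- compound 2 `Nc1nc(N)c2c(-c3cccs3)cn([C@@H]3O[C@H](CO)[C@@H](O)[C@H]3O)c2n1` gives > 100000 nM as a limit
- compound 3 `COc1nc(N)nc2c1c(-c1cccs1)cn2[C@@H]1O[C@H](CO)[C@@H](O)[C@H]1O` gives 99900 nM as a number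

Compound 3 at 99900 nM is the higher of the two actual numbers, and compound 1 lies lower, beyond the scatter. Compound 4 `COc1nc(N)nc2c1c(-c1cc3ccccc3o1)cn2[C@@H]1O[C@H](CO)[C@@H](O)[C@H]1O` follows from compound 3 by a single change (1-benzofuran-2-yl in place of thiophen-2-yl on an aromatic carbon) on an aromatic carbon of the shared core. Going by the values given here, the only measured step, a number no higher from compound 2 to compound 3 (the limit leaves the size open) with methoxy in place of amino, concerns another place and gives no readable size for this change. The nearest guide is compound 1 at 22400 nM which carries 1-benzofuran-2-yl but lacks the amino group of compound 3. In this assay a move to a lower number, probably beyond the scatter, is therefore expected, with limited confidence. The expected step is a 3.3-fold lower number from compound 3 to compound 4 (0.52 log units; beyond the scatter) on this single comparison. For compound 4 the estimate is 30000 nM with an expected range from 12000 nM to 80000 nM in this assay.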

Compound 4, half-maximal inhibitory concentration: 25600 nM
Beside the measured number, compound 4's estimate is 1.2-fold (0.07 log units) above it; the measured number falls inside the stated range.
By their numbers in this assay, from the lowest: compounds 1 and 4 (each within the scatter of the next); then compound 3. At a limit, above all of these: compound 2.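

In this assay the aromatic carbon two ring bonds from the ring nitrogen now has a readable step: 1-benzofuran-2-yl in place of thiophen-2-yl gives a 3.9-fold lower number from compound 3 to compound 4 (0.59 log units; beyond the scatter) and so shows that the group at this place can move the number beyond the scatter. With 1-benzofuran-2-yl present, amino in place of hydrogen on an aromatic carbon gives a 1.1-fold higher number from compound 1 to compound 4 (0.06 log units; within the scatter) and so separates the two compounds by no more than the scatter. No measurement shown accounts for either step.

The step to compound 4 changes sulfur to oxygen and adds a six-membered aromatic ring together, and furan-2-yl or 1-benzothiophen-2-yl would be needed to separate the two. From the compounds shown here alone, how an amine or a carboxylic acid on the 1-benzofuran-2-yl group would read also remains open.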